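Methoxy removal on the aryl amide and amine acid dissociation

A few compounds are considered here, and "the series" means these few. Any claim that something is new, unique, unknown or untested is made for them only; others in the source may bear on it.

Measured compounds:
compound 1 `COc1cc(C(=O)N[C@@H]2CCC[C@@H]3CCN(C)C[C@H]32)cc(OC)c1OC` gives 8.75
compound 2 `CN1CC[C@H]2CCC[C@@H](NC(=O)c3ccccc3)[C@H]2C1` gives 9.18
compound 3 `COc1ccccc1C(=O)N[C@@H]1CCC[C@@H]2CCN(C)C[C@@H]21` gives 9.11

All three numbers come from a physicochemical assay for acid dissociation. Compound 1 stands lowest of the three; compound 3 lies nearest to it and compound 2 furthest, both gaps beyond the scatter. The difference between the core of compound 1 and the core of compound 3 is not broken down here.

One structural change recurs twice in the set. From compound 3 to compound 2 it is hydrogen in place of methoxy on an aromatic carbon, and the step is a number 0.07 log units higher from compound 3 to compound 2 (within the scatter). From compound 1 to compound 4 `COc1ccc(C(=O)N[C@@H]2CCC[C@@H]3CCN(C)C[C@H]32)cc1OC` it is hydrogen in place of methoxy on an aromatic carbon. The two are the same kind of change, not the same: in compound 3 the leaving methoxy sits ortho to a large group, whereas in compound 1 it sits ortho to a methoxy group, meta to a large group and meta to a methoxy group.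

For compound 4 a step in the same direction as before is expected, and the estimate is a number 0.15 log units higher from compound 1 to compound 4 (within the scatter), resting on the near-flat step from compound 3 to compound 2 and on the gap between compound 1 and compound 2 at 9.18, which caps how far removing a single methoxy could carry. Compound 4 is therefore expected to give 8.9, with a range from 8.6 to 9.2.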

Compound 4, acid dissociation constant: 8.89
The estimate for compound 4 lay 0.01 log units above the measured number; the measured number falls inside the stated range.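

In this assay hydrogen in place of methoxy on an aromatic carbon gives a number 0.14 log units higher from compound 1 to compound 4 (within the scatter) and, on the other core, a number 0.07 log units higher from compound 3 to compound 2 (within the scatter) and neither step can be told apart from repeat measurement. Across these two pairs the change therefore carries from one core to the other only in the limited sense that neither core shows a readable shift. Among the compounds shown here, this does not show that the two cores respond alike in general: there are only two pairs, the leaving methoxy has different surroundings in each, and nothing measured here bears on what lies behind either step.

The compounds shown leave open whether the core of compound 1 stays equally flat when a second or third methoxy group gives way to hydrogen, and whether the same aryl amide on both cores would give matching numbers. They also leave open what happens when the methoxy in compound 1 is replaced by something other than hydrogen, such as fluorine, an amine or a carboxylic acid, since a replacement of that kind might give a step beyond the scatter.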